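Furan-2-yl to phenyl on the shared core

The source may hold more compounds than are shown below. What is called first, only, known or untested is meant among the compounds shown, and "the series" means these compounds.

Values so far in a functional assay on K562 cells (Homo sapiens), read by MTT assay, with a stated time of 72 h (on this read-out lower numbers stand for stronger inhibition and higher numbers for weaker inhibition), so far:
- compound 1 `CSc1ncnc2c1c(-c1ccoc1)cn2[C@@H]1O[C@H](CO)[C@@H](O)[C@H]1O` gives 3250 nM
- compound 2 `CNc1ncnc2c1c(-c1ccco1)cn2[C@@H]1O[C@H](CO)[C@@H](O)[C@H]1O` gives 15100 nM

Compound 2 holds the higher of the two numbers, beyond the scatter from compound 1, but these two differ in more than one place. Next comes compound 3 `CNc1ncnc2c1c(-c1ccccc1)cn2[C@@H]1O[C@H](CO)[C@@H](O)[C@H]1O` with phenyl in place of furan-2-yl on an aromatic carbon and the rest unchanged. Going by the values given here, no measured step covers this change. In this assay no step beyond the scatter is expected, with a slight rise as the likelier direction. The expected move is a 1.3-fold higher number from compound 2 to compound 3 (0.12 log units; within the scatter) in this estimate. For compound 3 the estimated value is 20000 nM with an expected range from 6000 nM to 60000 nM in these notes.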

Compound 3, half-maximal inhibitory concentration: > 20000 nM
Compound 3: a limit, no number (the forecaster's own chance of this, stated with the estimate: 25%); the middle value lies on the limit itself.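

In this assay, going by these compounds alone, this is the first single-place step at this aromatic carbon: phenyl in place of furan-2-yl gives an at least 1.3-fold higher number from compound 2 to compound 3 (0.12 log units; that floor lies within the scatter), a floor that lies within the scatter. The step brings no fall in the number, but its true size cannot be read. The reading for compound 3 is a limit of the assay, not a number: the limit of > 20000 nM in this assay, at which 1 of the 3 values shown sits.

From the compounds shown here alone, how far compound 3 lies past that limit stays open. Also open, going by these compounds, is how a pyridin-3-yl ring or a methyl group at this carbon would read in this assay.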